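A few compounds are considered here, and "the series" means these few. Any claim that something is new, unique, unknown or untested is made for them only; others in the source may bear on it.

The study follows an antiproliferative series built on one shared core, read in a functional assay on A549 cells (Homo sapiens) for antiproliferative activity, read by MTT assay, with a stated time of 72 h; a higher number here means a weaker inhibitor, a lower number a stronger inhibitor. Compound 1 `CN(C(=O)c1ccccc1)c1ccc2[nH]c(-c3n[nH]c4ccccc34)cc2n1` gives 13800 nM in this assay. Compound 2 `CN(C(=O)c1ccccc1)c1ccc2[nH]c(-c3n[nH]c4cc(Cl)ccc34)cc2n1` gives 9590 nM, and compound 3 `COc1ccc(S(=O)(=O)N(C)c2ccc3[nH]c(-c4n[nH]c5ccccc45)cc3n2)cc1` gives 24300 nM. Among the three numbers, compound 1 sits second highest, with compound 2 nearest and compound 3 furthest, yet both of those gaps fall within the usual scatter, so the three measured compounds cannot be separated from one another on these data.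

Within the data shown here, the one step that joins two measured compounds, a 1.4-fold lower number from compound 1 to compound 2 (0.16 log units; within the scatter), concerns a chloro in place of hydrogen on an aromatic carbon and stays within the scatter.

Compound 4 `CN(C(=O)Nc1ccccc1)c1ccc2[nH]c(-c3n[nH]c4ccccc34)cc2n1` differs from compound 1 at the carbonyl carbon: anilino in place of phenyl on a carbonyl carbon. Among the measured compounds shown here, no measured step touches this carbonyl position; the only measured step concerns a different part of the core, and the pair compound 1 and compound 3 shows values within the scatter of each other without any single-point comparison. There is therefore nothing in the data that would point to a change beyond the scatter in this assay.

On this basis compound 4 is expected to give about 13000 nM in this assay, with a range from 5000 nM to 35000 nM. The step this estimate implies, a 1.1-fold lower number from compound 1 to compound 4 (0.03 log units; within the scatter), is expected to stay within the scatter.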

Compound 4, half-maximal inhibitory concentration: 1430 nM
Estimate against measurement, compound 4: 9.1-fold (0.96 log units) above, outside the stated range (below it).
By their numbers in this assay, from the lowest: compound 4; then compounds 2, 1 and 3 (each within the scatter of the next, the first and the last beyond it).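

In this assay, the position on the carbonyl carbon proves responsive: anilino in place of phenyl, which turns benzoyl into phenylcarbamoyl, gives a 9.7-fold lower number from compound 1 to compound 4 (0.98 log units; beyond the scatter) and is the only step shown that lies beyond the scatter. The other step, chloro in place of hydrogen on an aromatic carbon, gives a 1.4-fold lower number from compound 1 to compound 2 (0.16 log units; within the scatter) and does not separate its two compounds, so this result provides the first clear structural signal in the series, tied to a change that keeps the six-membered aromatic ring of carbon and adds one nitrogen carrying a hydrogen-bond donor. Nothing measured here bears on why this exchange has such an effect.

The compounds shown leave open whether the gain depends on the amide hydrogen or on the aromatic ring beyond it, a question that methylanilino, phenoxy or cyclohexylamino on the same carbonyl carbon would help to address. They also leave open whether the anilino gain would carry over to the chloro-bearing core of compound 2.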